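Shifting the chloro group on a sulfonamide orexin agonist

The source may hold more compounds than are shown below. What is called first, only, known or untested is meant among the compounds shown, and "the series" means these compounds.

Compound 3 `COc1ccc(-c2cccc(C(=O)N(C)C)c2)cc1S(=O)(=O)Nc1cccc(NCCNC(=O)c2ccccc2Cl)c1` stands at the top of the three numbers in a functional assay on CHO-K1 cells for agonist activity at Orexin receptor type 2 (Homo sapiens), read by calcium flux (on this read-out higher numbers stand for larger maximal responses and lower numbers for smaller maximal responses), with 90%. Compound 2 `COc1ccc(-c2cccc(C(=O)N(C)C)c2)cc1S(=O)(=O)Nc1cccc(NCCNC(=O)c2ccccc2C)c1` gives 85%, and the step of a number 5 percentage points higher from compound 2 to compound 3 (within the scatter) lies within the scatter, whereas compound 1 `COc1ccccc1C(=O)NCCNc1cccc(NS(=O)(=O)c2cc(-c3cccc(C(=O)N(C)C)c3)ccc2OC)c1` gives 74% and the step of a number 16 percentage points higher from compound 1 to compound 3 (beyond the scatter) lies beyond it. Compound 4 `COc1ccc(-c2cccc(C(=O)N(C)C)c2)cc1S(=O)(=O)Nc1cccc(NCCNC(=O)c2cccc(Cl)c2)c1` differs from compound 3 by 3-chlorophenyl in place of 2-chlorophenyl on a carbonyl carbon. Every measured step, including a number 11 percentage points higher from compound 1 to compound 2 (beyond the scatter), exchanged one group for another at one and the same place; none changed where the group sits, so no direct guide exists. The step of a number 7 percentage points lower from compound 3 to compound 4 (within the scatter) is therefore expected to remain within the scatter. The estimate for compound 4 is 83%, ranging from 66% to 96%.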

Compound 4, largest response reached (Emax), in percent of the reference or control that the assay uses: 78%
For compound 4 the middle estimate is 5 percentage points above the measured one; the range from low to high includes it.
By their numbers in this assay, from the lowest: compounds 1, 4, 2 and 3 (each within the scatter of the next, the first and the last beyond it).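

Moving the chloro group, from 2-chlorophenyl to 3-chlorophenyl on a carbonyl carbon with the atoms unchanged, gives a number 12 percentage points lower from compound 3 to compound 4 (beyond the scatter) in this assay, so at this place the response depends on where the group sits as well as on which group it is. The other two comparisons, a number 7 percentage points lower from compound 2 to compound 4 (within the scatter) and a number 4 percentage points higher from compound 1 to compound 4 (within the scatter), stay within the scatter. Nothing available explains this shift. The compounds shown leave open whether methyl or methoxy would respond to the same move, and what a bromo group or an amine on that ring would give.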